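Swapping the amide substituent in a cytotoxicity series

The compounds below may be only part of what the source reports. "The series", "measured", "known", "first", "only" and "open" are said of these compounds alone.

Compound 1, `C=CC1=C(C(=O)NCCCCC)C(c2ccc(OC)cc2)OC1`, reaches only the limit > 100000 nM in a functional assay on SW480 cells (Homo sapiens) for cytotoxicity, read by MTT assay, with a stated time of 24 h; a lower number here means a stronger inhibitor, a higher number a weaker inhibitor.
Compound 2, `C=CC1=C(C(=O)NCc2ccccc2F)C(c2ccc(F)cc2)OC1`, likewise reaches only the limit > 100000 nM.
Compound 3, `C=CC1=C(C(=O)Nc2ccc(OCC)cc2)C(c2ccc(OC)cc2)OC1`, also reaches only the limit > 100000 nM.

Compound 3 therefore stands nowhere definite: its value is a limit of the assay, and the two other values shown are limits as well. Within the data shown here, the one step that could be compared, a step that the two limits leave unreadable from compound 1 to compound 3, is unreadable, since the limit of > 100000 nM in this assay, at which 3 of the 3 values shown sit, hides any real difference.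

Compound 4, `C=CC1=C(C(=O)NCc2ccccc2F)C(c2ccc(OC)cc2)OC1`, changes compound 3 in one place: 2-fluorobenzyl in place of 4-ethoxyphenyl on an amide-type nitrogen. Compound 2 carries the same 2-fluorobenzyl group on its amide-type nitrogen and, as shown, also gives only a limit. Among the measured compounds shown here, no measured step speaks for a change in either direction, so the step that the limit leaves unreadable from compound 3 to compound 4 is expected to be none beyond the scatter. Compound 4 is expected to sit at the limit again, with an estimate of 150000 nM and a range from 60000 nM to 600000 nM.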

Compound 4, half-maximal inhibitory concentration: > 100000 nM
Compound 4 was reported as a limit; the forecaster's own chance of this, stated with the estimate: 80%; the middle value does not contradict the limit.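

Compound 4 gives only a limit, so its steps from compound 1, compound 2 and compound 3 cannot be read, because every value shown is a limit: the limit of > 100000 nM in this assay, at which 4 of the 4 values shown sit. In this assay the compounds shown leave open whether any group on the amide-type nitrogen gives a readable value.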